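A Methyl Shift on a Fused Ring and Solubility

The source may report more compounds than this note shows. Statements on the series, on what has been measured and on what is new or still open speak of the compounds shown alone.

Compound 1, `CC(C)Nc1nc(NCc2ccco2)c2ccccc2n1`: in a physicochemical assay for solubility, at pH 7.4 (a higher number here means a more soluble compound, a lower number a less soluble compound), compound 1 gives >= 30000 nM, which is a limit of the assay.
Compound 2, `CCOC(=O)CNc1nc(NC(C)C)nc2ccccc12`: in this assay compound 2 gives <= 20000 nM, which is a limit of the assay.
Compound 3, `Cc1cccc2c(NCc3ccco3)nc(NC(C)C)nc12`: in this assay compound 3 gives <= 20000 nM, which is a limit of the assay.

Within the data shown here, compound 1 stands only at a limit, the one where a single value sits (the limit of >= 30000 nM in this assay, at which 1 of the 3 values shown sits), while the two other compounds sit at the opposite limit (the limit of <= 20000 nM in this assay, at which 2 of the 3 values shown sit). Two steps lead away from compound 1. Exchanging ethoxycarbonyl for furan-2-yl on the saturated chain carbon bound to a ring nitrogen gives an at least 1.5-fold lower number from compound 1 to compound 2 (0.17 log units; that floor lies within the scatter). Adding methyl in place of hydrogen on an aromatic carbon gives an at least 1.5-fold lower number from compound 1 to compound 3 (0.17 log units; that floor lies within the scatter).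

Compound 4, `Cc1cccc2nc(NC(C)C)nc(NCc3ccco3)c12`, is not yet measured. It differs from compound 1 by methyl in place of hydrogen on an aromatic carbon. The step from compound 1 to compound 3 is the same kind of change, a methyl on an aromatic carbon of the shared core, and it bears most directly here; the step from compound 1 to compound 2 is a different exchange and is only background. A drop of similar size is expected, an at least 2.0-fold lower number from compound 1 to compound 4 (0.30 log units; that floor lies within the scatter), quite possibly again reaching a limit. The estimate for compound 4 is 15000 nM, with a range from 5000 nM to 30000 nM.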

Compound 4, solubility: <= 10000 nM
Compound 4: only a limit was reported; the forecaster's own chance of this, stated with the estimate: 70%; middle value at least 1.5-fold (0.17 log units) away from the limit.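

In this assay, methyl in place of hydrogen on this aromatic carbon, ortho to a fused ring and meta to a fused ring, gives an at least 3.0-fold lower number from compound 1 to compound 4 (0.47 log units; beyond the scatter). The earlier methyl step on the shared core could not show a change of this size, since it gives only an at least 1.5-fold lower number from compound 1 to compound 3 (0.17 log units; that floor lies within the scatter). A step beyond the scatter therefore goes here with the entry of a single carbon, with no ring, no hydrogen-bond donor or acceptor and no net charge; both ends of the step are limits of the assay, and its printed size is a floor.

As far as these compounds go, compound 3 and compound 4 both stand at limits, so how the two methyl placements compare remains open, as does the actual value of compound 4. Also open, from the compounds shown here alone, is how this carbon responds to groups other than methyl, such as an amine, a carboxylic acid or a longer chain, and whether any of them would keep the number near that of compound 1 or take it further down.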